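The source may report more compounds than this note shows. Statements on the series, on what has been measured and on what is new or still open speak of the compounds shown alone.

Three compounds sharing one core have been run in a functional assay on HCC1937 cells (Homo sapiens) for antiproliferative activity, read by CCK-8 assay, with a stated time of 72 h; on this read-out higher numbers stand for weaker inhibition and lower numbers for stronger inhibition. Compound 1 `O=C(Nc1cccc(-c2oc3cc(-c4ccc(F)cc4)ccc3c(=O)c2O)c1)c1ccc(C(F)(F)F)cc1` gives 7350 nM, compound 2 `O=C(Nc1cccc(-c2oc3cc(-c4ccc(F)cc4)ccc3c(=O)c2O)c1)c1ccc(Br)cc1` gives 8630 nM, and compound 3 `COc1cc(OC)cc(C(=O)Nc2cccc(-c3oc4cc(-c5ccc(F)cc5)ccc4c(=O)c3O)c2)c1` gives 6250 nM. Compound 3 holds the lowest of the three numbers, yet both gaps to it are within the scatter: a 1.2-fold lower number from compound 1 to compound 3 (0.07 log units; within the scatter) and a 1.4-fold lower number from compound 2 to compound 3 (0.14 log units; within the scatter). Compound 4 `O=C(Nc1cccc(-c2oc3cc(-c4ccc(F)cc4)ccc3c(=O)c2O)c1)c1ccc(Cl)nc1` differs from compound 3 by 6-chloropyridin-3-yl in place of 3,5-dimethoxyphenyl on a carbonyl carbon. The two earlier replacements of the aryl group on that carbonyl carbon moved this assay by amounts within the scatter, so no step beyond the scatter is expected here either. Compound 4 is accordingly estimated at 7000 nM, with a range from 3500 nM to 14000 nM. The expected step is a 1.1-fold higher number from compound 3 to compound 4 (0.05 log units; within the scatter).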

Compound 4, half-maximal inhibitory concentration: 7550 nM
Estimate against measurement, compound 4: 1.1-fold (0.03 log units) below; the range from low to high includes it.
By their numbers in this assay, from the lowest: compounds 3, 1, 4 and 2 (each within the scatter of the next).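

In this assay, the 6-chloropyridin-3-yl group, unlike the three all-carbon aryl groups before it, brings a ring hetero atom onto the carbonyl carbon, and the number stays within the scatter of all three (a 1.2-fold higher number from compound 3 to compound 4 (0.08 log units; within the scatter); a 1.1-fold lower number from compound 2 to compound 4 (0.06 log units; within the scatter); a 1.0-fold higher number from compound 1 to compound 4 (0.01 log units; within the scatter)). For the compounds shown here, at this position, then, swapping a carbon-only ring for a pyridine ring, with fewer heavy atoms than 3,5-dimethoxyphenyl, produces no step that can be told from scatter. Nothing available explains this flat response. On these data alone, whether a saturated group such as a piperidine, or an aryl group carrying a carboxylic acid, on that carbonyl carbon would produce a step beyond the scatter stays open.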